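Adding a Hydroxy Group to an Inactive Chlorobutanamide

The source may hold more compounds than are shown below. What is called first, only, known or untested is meant among the compounds shown, and "the series" means these compounds.

Compound 1, `CCCCC(O)c1cccc(NC(=O)NC(=O)CC)c1`: > 100000 nM
Compound 2, `CCCCCc1cccc(NC(=O)CCCCl)c1`: > 100000 nM

Of the compounds shown here, two have been tested in a functional assay on MCF7 cells (Homo sapiens) for antiproliferative activity, with a stated time of 48 h; on this read-out higher numbers stand for weaker inhibition and lower numbers for stronger inhibition. For compound 1 the value > 100000 nM is a limit of the assay, not a measured number. For compound 2 the value > 100000 nM is likewise a limit. Compound 2 therefore stands at the limit of > 100000 nM in this assay, at which 2 of the 2 values shown sit, so neither tested compound shows measurable inhibition.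

Compound 3, `CCCCC(O)c1cccc(NC(=O)CCCCl)c1`, is the next to be measured. It differs from compound 2 in one place: hydroxy in place of hydrogen on a saturated chain carbon bound to an aromatic carbon and a saturated chain carbon. Within the data shown here, no step between measured compounds exists, so the effect of this change rests on the two limits alone. Compound 1, which carries the same hydroxy group, also sits at the limit. The expected step is a number no higher from compound 2 to compound 3 (the limit leaves the size open), meaning no change beyond the scatter. The estimate for compound 3 in this assay is 100000 nM, with a range from 30000 nM to 300000 nM.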

Compound 3, half-maximal inhibitory concentration: > 100000 nM
Compound 3 ended at the assay's limit; the forecaster's own chance of this, stated with the estimate: 80%; the middle value sits exactly at the limit.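

In this assay the values of compound 1, compound 2 and compound 3 are all limits and not numbers, so no step among these compounds can be read. The compounds shown leave open whether the hydroxy group has any effect on inhibition at all.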